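A Nitro-to-Amino Swap on the Chlorinated Compound

The compounds below may be only part of what the source reports. "The series", "measured", "known", "first", "only" and "open" are said of these compounds alone.

Measured in a functional assay on P388 cells (Mus musculus) for antiproliferative activity, read by colorimetric assay and MTT assay; on this read-out lower numbers stand for stronger inhibition and higher numbers for weaker inhibition:
- compound 1 `O=[N+]([O-])c1ccc(S(=O)(=O)Nc2cccc3cc[nH]c23)cc1`: 8.2 ug/mL
- compound 2 `O=[N+]([O-])c1ccc(S(=O)(=O)Nc2cccc3c(Cl)c[nH]c23)cc1`: 2.3 ug/mL

Of these two numbers, compound 2 holds the lower one at 2.3 ug/mL, and the gap to compound 1 lies beyond the scatter. The next compound to be tested is compound 3 `Nc1ccc(S(=O)(=O)Nc2cccc3c(Cl)c[nH]c23)cc1`, which has not yet been measured. It differs from compound 2 by a single change: amino in place of nitro on an aromatic carbon. In words, this is amino in place of nitro on an aromatic carbon.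

Among the measured compounds shown here, only one measured step is available as a guide, a 3.6-fold lower number from compound 1 to compound 2 (0.55 log units; beyond the scatter). That step was modest, and it was a chloro in place of hydrogen, so it is a different change at a different place. For the measured compounds named here, no measured step replaces the nitro group, so the data give no direction for this swap. No shift beyond the scatter is therefore expected in this assay, although the uncertainty is wide. The expected change is a 1.2-fold lower number from compound 2 to compound 3 (0.06 log units; within the scatter). For compound 3 the estimated value is 2 ug/mL, with an expected range from 0.5 ug/mL to 8 ug/mL.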

Compound 3, half-maximal inhibitory concentration: 0.81 ug/mL
Estimate against measurement, compound 3: 2.5-fold (0.39 log units) above; measured number inside the range.
By their numbers in this assay, from the lowest: compound 3; then compound 2; then compound 1.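

In this assay, this position on the six-membered aromatic ring of carbon only, para to a large group, proves open to change: nitro is not required there, since amino in its place gives a 2.8-fold lower number from compound 2 to compound 3 (0.45 log units; beyond the scatter). Among the compounds shown here, this is the first measured change at this position, and it shows that the chloro step, a 3.6-fold lower number from compound 1 to compound 2 (0.55 log units; beyond the scatter), is not the only single change that moves the number beyond the scatter, so a second place on these compounds also bears on the read-out. No measurement shown here explains why the swap lowers the number.

The compounds shown do not tell whether the shift comes from the presence of amino or simply from the absence of nitro, a question that hydrogen, methoxy or an acetamide at this position would help to settle. Also open, on these data alone, is whether amino in place of nitro would give a similar step on the core of compound 1, which carries hydrogen where compound 2 carries chloro.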